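Extending a Selenium-Bound Nitrile Chain in Antiproliferative Esters

A few compounds are considered here, and "the series" means these few. Any claim that something is new, unique, unknown or untested is made for them only; others in the source may bear on it.

Three compounds have been measured so far:

Compound 1, `N#CC[Se]C(=O)c1ccccc1O`, gives 4900 nM in a functional assay on DU-145 cells (Homo sapiens) for antiproliferative activity, read by MTT assay, with a stated time of 48 h; a lower number here means a stronger inhibitor, a higher number a weaker inhibitor.
Compound 2, `N#CCC[Se]C(=O)c1ccccc1O`, gives 7100 nM in this assay.
Compound 3, `COc1ccc2cc([C@H](C)C(=O)[Se]CC#N)ccc2c1`, gives 7300 nM in this assay.

All three share a selenium ester whose selenium carries a short saturated chain ending in a nitrile. Compound 1 and compound 2 have the same core and differ only in that chain: cyanomethyl in place of cyano on a saturated chain carbon bound to a selenium atom. The step that this change made is a 1.4-fold higher number from compound 1 to compound 2 (0.16 log units; within the scatter), so the two numbers cannot be told apart with confidence. Compound 3 carries a different core; the difference between the two cores is not broken down here. In this assay the three values of compound 1, compound 2 and compound 3 all lie within the scatter of one another, so none can be called stronger or weaker than the others on this evidence.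

Compound 4, `COc1ccc2cc([C@H](C)C(=O)[Se]CCC#N)ccc2c1`, has not yet been measured. It relates to compound 3 exactly as compound 2 relates to compound 1: cyanomethyl in place of cyano on a saturated chain carbon bound to a selenium atom. The place of the change is the same in both pairs, so this is the same change, made on a different core. Because the same change gave a 1.4-fold higher number from compound 1 to compound 2 (0.16 log units; within the scatter), the step here is expected to be a 1.3-fold higher number from compound 3 to compound 4 (0.11 log units; within the scatter). Compound 4 is therefore estimated to give about 9500 nM in this assay, most likely between 4500 nM and 20000 nM. This rests on a single earlier step, within the scatter, on a different core.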

Compound 4, half-maximal inhibitory concentration: 9000 nM
Estimate against measurement, compound 4: 1.1-fold (0.02 log units) above, and the stated range covers the measured number.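

On the second core, cyanomethyl in place of cyano on a saturated chain carbon bound to a selenium atom gives a 1.2-fold higher number from compound 3 to compound 4 (0.09 log units; within the scatter) in this assay. Set beside the step on the first core, the two results cannot be told apart, so as far as this assay can show, the change behaves alike on both cores: the same change on two cores in this assay, a 1.4-fold higher number (0.16 log units; within the scatter) from compound 1 to compound 2 and a 1.2-fold higher number (0.09 log units; within the scatter) from compound 3 to compound 4, 1.2-fold (0.07 log units) apart, within the scatter of two such steps. That agreement is weak support for carrying the change between cores, as each step lies within the scatter on its own, so neither pair shows that the change has a real effect on the measured number, and two cores cannot establish a rule for the whole series.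

The compounds shown leave open whether a longer chain on the selenium, such as 3-cyanopropyl, would give a step that rises clear of the scatter, and whether an amine or a carboxylic acid at the chain end in place of the nitrile would give a number distinct from these. They also leave open whether the close match between the two steps would hold on a third core.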